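Swapping oxolanyl for cyclopropyl on a kinase inhibitor core

A few compounds are considered here, and "the series" means these few. Any claim that something is new, unique, unknown or untested is made for them only; others in the source may bear on it.

Compound 1 `Nc1ncc(-c2cc([C@@H]3CCCO3)nc(N3C[C@@H]4C[C@H]3CO4)n2)nc1OC(F)F` gives 23 nM
Compound 2 `CSc1cc(-c2cnc(N)c(OC(F)F)n2)nc(N2C[C@@H]3C[C@H]2CO3)n1` gives 45 nM
Compound 3 `Nc1ncc(-c2cc([C@H]3CCCO3)nc(N3C[C@@H]4C[C@H]3CO4)n2)nc1OC(F)F` gives 202 nM

All three numbers come from an assay on Sf21 cells for inhibition of mitogen-activated protein kinase kinase kinase 13 (Homo sapiens), read by HTRF, with a stated time of 1.5 h; on this read-out higher numbers stand for weaker inhibition and lower numbers for stronger inhibition. Compound 3 stands highest of the three, its nearest neighbour being compound 2 and its furthest compound 1. The two steps that reach it are an 8.8-fold higher number from compound 1 to compound 3 (0.94 log units; beyond the scatter) and a 4.5-fold higher number from compound 2 to compound 3 (0.65 log units; beyond the scatter), and the first of these rests on nothing more than the fact that compounds 1 and 3 differ only in the configuration as drawn. The step from compound 1 to compound 2, a 2.0-fold higher number from compound 1 to compound 2 (0.29 log units; within the scatter), shows that the oxolan-2-yl and methylsulfanyl groups on that aromatic carbon give numbers close to each other when the oxolanyl is drawn in its better configuration.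

Compound 4 `Nc1ncc(-c2cc(C3CC3)nc(N3C[C@@H]4C[C@H]3CO4)n2)nc1OC(F)F` differs from compound 3 by cyclopropyl in place of oxolan-2-yl on an aromatic carbon. The change removes the stereocentre that sets compound 3 apart from compound 1, and it exchanges a group at the same aromatic carbon where the step from compound 2 to compound 3 was made. Both comparisons point the same way: a group without that stereocentre at this position has so far given the lower numbers. Compound 4 is therefore expected to return a lower number than compound 3, by about a 4.0-fold lower number from compound 3 to compound 4 (0.61 log units; beyond the scatter), though the scatter of single measurements leaves that step uncertain in size. The estimate for compound 4 in this assay is 50 nM, within a range of 15 nM to 160 nM.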

Compound 4, half-maximal inhibitory concentration: 61 nM
Compound 4: middle estimate off by 1.2-fold (0.09 log units), on the low side, and the stated range covers the measured number.
By their numbers in this assay, from the lowest: compounds 1, 2 and 4 (each within the scatter of the next, the first and the last beyond it); then compound 3.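

In this assay, cyclopropyl, which carries no stereocentre, gives a number that falls between those of the two oxolan-2-yl forms at this aromatic carbon: a 3.3-fold lower number from compound 3 to compound 4 (0.52 log units; beyond the scatter) on one side and a 2.7-fold higher number from compound 1 to compound 4 (0.42 log units; beyond the scatter) on the other. Set against methylsulfanyl, the same position gives a 1.4-fold higher number from compound 2 to compound 4 (0.13 log units; within the scatter), so this read-out does not separate cyclopropyl from methylsulfanyl. Oxolan-2-yl therefore cannot be ranked against cyclopropyl as a single group, and the direction of that comparison changes with the configuration drawn at its ring carbon, a reading that holds because nothing else separates the two oxolan-2-yl compounds: the fact that compounds 1 and 3 differ only in the configuration as drawn.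

Still open, from the compounds shown here alone, is whether the ring oxygen of oxolan-2-yl contributes to the number at all, as cyclopropyl differs from it in both ring size and that oxygen, and cyclopentyl at the same carbon would separate the two. Also open, going by these compounds, is how a methoxy group or a dimethylamino group at this carbon would compare with methylsulfanyl and cyclopropyl.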